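Compound 2 to compound 4: one methyl removed

The source may report more compounds than this note shows. Statements on the series, on what has been measured and on what is new or still open speak of the compounds shown alone.

Compound 1 `Cc1ccc(-c2nn(-c3ccccc3)cc2C(Nc2nc3cc(C)c(C)cc3s2)c2c(O)ccc3ccccc23)cc1`: 22400 nM
Compound 2 `Cc1cc2nc(NC(c3cn(-c4ccccc4)nc3-c3ccc([N+](=O)[O-])cc3)c3c(O)ccc4ccccc34)sc2cc1C`: 41100 nM
Compound 3 `COc1ccc2nc(NC(c3cn(-c4ccccc4)nc3-c3ccccc3)c3c(O)ccc4ccccc34)sc2c1`: 40800 nM

In a functional assay on MCF7 cells (Homo sapiens) for antiproliferative activity, read by MTT assay, with a stated time of 48 h (a lower number here means a stronger inhibitor, a higher number a weaker inhibitor), compound 2 gives 41100 nM, within the scatter of both compound 1 and compound 3. The next compound is compound 4 `Cc1ccc2nc(NC(c3cn(-c4ccccc4)nc3-c3ccc([N+](=O)[O-])cc3)c3c(O)ccc4ccccc34)sc2c1`, with hydrogen in place of methyl on an aromatic carbon. Among the compounds with values here, the only measured single-place step, a 1.8-fold higher number from compound 1 to compound 2 (0.26 log units; within the scatter), is a different change, nitro in place of methyl on an aromatic carbon. Within the data shown here, no measured step covers this methyl directly, so the series offers no ground for a shift. In this assay the expected step is a 1.1-fold lower number from compound 2 to compound 4 (0.03 log units; within the scatter), which means none beyond the scatter. Compound 4 is estimated at 38000 nM, with an expected range of 20000 nM to 75000 nM.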

Compound 4, half-maximal inhibitory concentration: 20700 nM
Estimate against measurement, compound 4: 1.8-fold (0.26 log units) above, within the range that was stated.
By their numbers in this assay, from the lowest: compounds 4, 1, 3 and 2 (each within the scatter of the next).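

In this assay, within the data shown here, going from the 5,6-dimethyl-1,3-benzothiazol-2-yl group to the 6-methyl-1,3-benzothiazol-2-yl group gives a 2.0-fold lower number from compound 2 to compound 4 (0.30 log units; within the scatter), the first measured step at this position. Within the compounds shown, this methyl can therefore be replaced by hydrogen without a change beyond the scatter. No available measurement bears on this result.

On these data alone, the step is read only with the nitro group present, so it remains unknown whether it holds with the methyl that compound 1 carries there. Also open, as far as these compounds go, is how an amine or a carboxylic acid at this position would read.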